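Fluoro in place of hydrogen on the benzyl ring

The source may report more compounds than this note shows. Statements on the series, on what has been measured and on what is new or still open speak of the compounds shown alone.

Compound 1 `Cc1ccc2[nH]cc(C3=CCN(Cc4ccc(OCC(=O)NO)cc4)CC3)c2c1` is the reference point of the series. For the measured compounds named here, in a functional assay on SW480 cells (Homo sapiens) for antiproliferative activity, with a stated time of 72 h (a lower number here means a stronger inhibitor, a higher number a weaker inhibitor), compound 1 gives 3960 nM, the only number so far, so it cannot be placed relative to any other member on the numbers alone. Compound 2 `Cc1[nH]c2cccc(F)c2c1C1=CCC(NCc2ccc(OCC(=O)NO)cc2F)CC1` carries the same hydroxamate unit on a different core and a different amine linkage, but in this assay compound 2 gives "nd" (no result reported), and nothing can be read from it.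

Compound 3 `Cc1ccc2[nH]cc(C3=CCN(Cc4ccc(OCC(=O)NO)cc4F)CC3)c2c1` keeps the core of compound 1 and differs only by fluoro in place of hydrogen on an aromatic carbon. Going by the values given here, no step between two measured compounds of this kind is available, so the expectation rests on compound 1 alone. The step of a 1.1-fold lower number from compound 1 to compound 3 (0.05 log units; within the scatter) is expected to stay within the usual scatter, with no clear direction. Compound 3 is therefore estimated at 3500 nM in this assay, within a range of 1400 nM to 9000 nM.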

Compound 3, half-maximal inhibitory concentration: 1950 nM
Compound 3: middle estimate off by 1.8-fold (0.25 log units), on the high side, and the stated range covers the measured number.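

In this assay, for the compounds shown here, fluoro in place of hydrogen on the aromatic carbon ortho to a large group and meta to a (hydroxycarbamoyl)methoxy group gives a 2.0-fold lower number from compound 1 to compound 3 (0.31 log units; beyond the scatter) and is the first readable step. The position therefore tolerates this single added heavy atom without loss of antiproliferative activity, and the change moves the number modestly towards a stronger inhibitor. No available measurement accounts for the step.

A single step does not show whether this gain is particular to fluoro or would extend to other groups on the same carbon, such as chloro, methoxy or an amine. Going by these compounds, it also remains open whether the same change gives a comparable step on a core other than that of compound 1.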